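A few compounds are considered here, and "the series" means these few. Any claim that something is new, unique, unknown or untested is made for them only; others in the source may bear on it.

Compound 1, `O=C(NCc1cn(Cc2ccc(Cl)cc2)nn1)c1cn(-c2ccccc2)nc1-c1ccccc1`: 8700 nM
Compound 2, `O=C(NCc1cn(Cc2ccc(C(F)(F)F)cc2)nn1)c1cn(-c2ccccc2)nc1-c1ccccc1`: 17700 nM
Compound 3, `COc1cc(Cn2cc(CNC(=O)c3cn(-c4ccccc4)nc3-c3ccccc3)nn2)cc(OC)c1`: 190 nM

In a functional assay on MIA PaCa-2 cells (Homo sapiens) for antiproliferative activity, read by sulforhodamine B assay, with a stated time of 48 h (a higher number here means a weaker inhibitor of growth, a lower number a stronger inhibitor of growth), compound 2 stands with the highest number of the three. Its nearest neighbour is compound 1, and the step of a 2.0-fold higher number from compound 1 to compound 2 (0.31 log units; beyond the scatter) is only modest, whereas compound 3 lies far away, as a 93-fold lower number from compound 2 to compound 3 (1.97 log units; beyond the scatter) shows. All three differ only in the aryl group carried on the saturated chain carbon bound to an aromatic nitrogen, and the large gains toward compound 3 come from that part of the molecule.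

Compound 4, `COc1ccc(-c2nn(-c3ccccc3)cc2C(=O)NCc2cn(Cc3ccc(C(F)(F)F)cc3)nn2)cc1`, keeps the 4-(trifluoromethyl)phenyl of compound 2 and changes a different part: methoxy in place of hydrogen on an aromatic carbon, so that a phenyl on the shared core becomes a 4-methoxyphenyl. Within the data shown here, none of the measured steps touches this ring; the steps of a 46-fold lower number from compound 1 to compound 3 (1.66 log units; beyond the scatter) and a 93-fold lower number from compound 2 to compound 3 (1.97 log units; beyond the scatter) concern methoxy groups on the other aryl ring and cannot be carried over. Among the measured compounds shown here, with no direct precedent, the step of a 1.5-fold lower number from compound 2 to compound 4 (0.17 log units; within the scatter) is expected to be small, within or near the scatter, and without a clear direction. Compound 4 is therefore estimated at 12000 nM, with a range from 4000 nM to 40000 nM.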

Compound 4, concentration for 50% growth inhibition: > 100000 nM
Compound 4: a limit, no number (the forecaster's own chance of this, stated with the estimate: 10%); at least 8.3-fold (0.92 log units) between middle value and limit.
By their numbers in this assay, from the lowest: compound 3; then compound 1; then compound 2. At a limit, above all of these: compound 4.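

In this assay, compound 4 is recorded only as a limit and not as a number: the limit of > 100000 nM in this assay, at which 1 of the 4 values shown sits. Even so, the step can be read as an at least 5.6-fold higher number from compound 2 to compound 4 (0.75 log units; beyond the scatter), which shows that the phenyl on the shared core is not a neutral place: changing phenyl to 4-methoxyphenyl, an addition of only 2 heavy atoms, weakens growth inhibition beyond the scatter. The earlier compounds shown here varied only the aryl group on the saturated chain carbon, where the 3,5-dimethoxyphenyl gave a 93-fold lower number from compound 2 to compound 3 (1.97 log units; beyond the scatter), so the effect of methoxy groups on that ring does not carry over to this one, where the direction is reversed.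

The compounds shown leave open how far beyond the limit compound 4 really lies, and whether the loss belongs to methoxy itself or would also appear with a hydroxyl, a fluoro or an amine on the same aromatic carbon. They also leave open whether 4-methoxyphenyl would cost as much on the core of compound 3, which carries the 3,5-dimethoxyphenyl.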